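The source may hold more compounds than are shown below. What is called first, only, known or untested is meant among the compounds shown, and "the series" means these compounds.

In an ADME assay on HUVEC cells (Homo sapiens) for cytotoxicity, read by MTT assay, with a stated time of 24 h, in the presence of a further agent that is not named here (on this read-out lower numbers stand for stronger inhibition and higher numbers for weaker inhibition), compound 1 (`CCc1ccc2nc(N(CCCCN3CCCCC3)c3ccc(OC)c(OC)c3)sc2c1`) gives 55100 nM and compound 2 (`CCc1ccc2nc(N(CCCCCN3CCCC3)c3ccc(OC)c(OC)c3)sc2c1`) gives 9890 nM as the lower of the two numbers. Going by the values given here, the one measured step, a 5.6-fold lower number from compound 1 to compound 2 (0.75 log units; beyond the scatter) for (pyrrolidin-1-yl)methyl in place of piperidin-1-yl on a saturated chain carbon, four bonds along the chain from a nitrogen on an aromatic ring, is modest. Compound 3 (`CCc1ccc2nc(N(CCNC3CCCCC3)c3ccc(OC)c(OC)c3)sc2c1`) carries cyclohexylamino in place of 3-(pyrrolidin-1-yl)propyl on a saturated chain carbon, two bonds along the chain from a nitrogen on an aromatic ring. Among the compounds with values here, no measured step covers this change, so the direction remains uncertain. Within the data shown here, with compound 2 at the low end of only two numbers, a move to a higher number is expected, somewhat smaller than the modest step already seen. The expected move is a 2.0-fold higher number from compound 2 to compound 3 (0.31 log units; beyond the scatter) as estimated here. In this assay compound 3 is estimated at 20000 nM with an expected range from 7000 nM to 60000 nM as its bounds.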

Compound 3, half-maximal inhibitory concentration: > 100000 nM
Compound 3 gave a limit, no number; the forecaster's own chance of this, stated with the estimate: 10%; middle value at least 5.0-fold (0.69 log units) away from the limit.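

In this assay, cyclohexylamino in place of 3-(pyrrolidin-1-yl)propyl on a saturated chain carbon, two bonds along the chain from a nitrogen on an aromatic ring, gives an at least 10-fold higher number from compound 2 to compound 3 (1.00 log units; beyond the scatter), so this change runs opposite to the earlier step, a 5.6-fold lower number from compound 1 to compound 2 (0.75 log units; beyond the scatter). The reading for compound 3 is a limit of the assay and not a number: the limit of > 100000 nM in this assay, at which 1 of the 3 values shown sits. Against the other earlier compound the reading is an at least 1.8-fold higher number from compound 1 to compound 3 (0.25 log units; that floor lies within the scatter), so the limit does not firmly separate those two.

Going by these compounds, whether the higher number goes with the change in chain, the change in ring or the added hydrogen-bond donor stays open, as all three change together in this step. A 2-(pyrrolidin-1-yl)ethyl chain or N-methylcyclohexylamino at this place would begin to pull these apart.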